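From 2-Carboxypiperidin-1-yl to 3-Carboxypyrrolidin-1-yl

The compounds below may be only part of what the source reports. "The series", "measured", "known", "first", "only" and "open" are said of these compounds alone.

Of the compounds shown here, three sharing one core have been measured in an ADME assay on HEK293 cells (Homo sapiens) for cytotoxicity, read by CCK-8 assay, with a stated time of 48 h; on this read-out lower numbers stand for stronger inhibition and higher numbers for weaker inhibition. Compound 1 (`COc1ccc(/C=C\c2cc(OC)c(OC)c(OC)c2)cc1OCc1ccc(C=O)cc1`) gives 46000 nM, compound 2 (`COc1ccc(/C=C\c2cc(OC)c(OC)c(OC)c2)cc1OCc1ccc(CN2CCCC[C@@H]2C(=O)O)cc1`) gives 42000 nM, and compound 3 (`COc1ccc(/C=C\c2cc(OC)c(OC)c(OC)c2)cc1OCc1ccc(CN2CCCCC2C(=O)NCCNC(=O)OC(C)(C)C)cc1`) gives 48000 nM. Compound 2 lies within the scatter of both other compounds, so the three values cannot be put in any order.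

Compound 4 (`COc1ccc(/C=C\c2cc(OC)c(OC)c(OC)c2)cc1OCc1ccc(CN2CC[C@H](C(=O)O)C2)cc1`) has not yet been measured. It carries 3-carboxypyrrolidin-1-yl in place of the 2-carboxypiperidin-1-yl of compound 2, on a saturated chain carbon bound to an aromatic carbon: 3-carboxypyrrolidin-1-yl in place of 2-carboxypiperidin-1-yl on a saturated chain carbon bound to an aromatic carbon.

Within the data shown here, only one measured step bears on this change, and only indirectly. Placing (2-carboxypiperidin-1-yl)methyl in place of formyl on an aromatic carbon gave a 1.1-fold lower number from compound 1 to compound 2 (0.04 log units; within the scatter). Among the measured compounds shown here, no measured pair varies the carboxylated ring itself, so the evidence is thin. No step beyond the scatter is expected in this assay, and the expected step is a 1.1-fold higher number from compound 2 to compound 4 (0.03 log units; within the scatter). The estimated value for compound 4 is 45000 nM, with an expected range of 25000 nM to 80000 nM.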

Compound 4, half-maximal inhibitory concentration: > 50000 nM
Compound 4 was reported as a limit; the forecaster's own chance of this, stated with the estimate: 15%; at least 1.1-fold (0.04 log units) between middle value and limit.
By their numbers in this assay, from the lowest: compounds 2, 1 and 3 (each within the scatter of the next). At a limit, above all of these: compound 4.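

In this assay compound 4 is reported only as a limit of the assay, not as a number: the limit of > 50000 nM in this assay, at which 1 of the 4 values shown sits. Setting 3-carboxypyrrolidin-1-yl in place of 2-carboxypiperidin-1-yl on a saturated chain carbon bound to an aromatic carbon gives an at least 1.1-fold higher number from compound 2 to compound 4 (0.07 log units; that floor lies within the scatter), and setting (3-carboxypyrrolidin-1-yl)methyl in place of formyl gives an at least 1.0-fold higher number from compound 1 to compound 4 (0.03 log units; that floor lies within the scatter). Among these compounds, this is the first change to the carboxylated ring itself, and it brings no lower number, though with only floors inside the scatter the true size of either step cannot be read.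

Compound 4 alters the ring size and the place of the carboxylic acid together, and the compounds shown do not separate the two. Also open, on these data alone, is how a primary amine or a tetrazole in place of the carboxylic acid on the five-membered ring would read.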